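This account rests on a few compounds, and the source may have more. Where it says the series, first, only, none or still open, it means among the compounds named here.

Compound 1 `O=[N+]([O-])c1ccc(-c2nccn2S(=O)(=O)c2ccccc2)cc1`: > 10000 nM (a limit)
Compound 2 `O=S(=O)(c1ccccc1)n1ccnc1-c1ccc(OCc2ccccc2)cc1`: > 10000 nM (a limit)

In a functional assay on PPC-1 cells (Homo sapiens) for cytotoxicity, read by sulforhodamine B assay, with a stated time of 48 h (on this read-out lower numbers stand for stronger inhibition and higher numbers for weaker inhibition), compound 2 gives > 10000 nM, which is a limit and not a number. Compound 3 `O=S(=O)(c1ccccc1)n1ccnc1-c1ccccc1` differs from compound 2 by hydrogen in place of benzyloxy on an aromatic carbon, para to a large group. Among the compounds with values here, the only measured step at this place is a step that the two limits leave unreadable from compound 1 to compound 2, so it offers no size to carry over. Evidence from compounds 1 and 2 is the limit of > 10000 nM in this assay, at which 2 of the 2 values shown sit, so a similar result is expected here, with no clear shift in either direction. The expected change is a step that the limit leaves unreadable from compound 2 to compound 3. For compound 3 the estimate is 14000 nM, within an expected range from 5000 nM to 40000 nM.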

Compound 3, half-maximal inhibitory concentration: > 10000 nM
Compound 3: a limit, no number (the forecaster's own chance of this, stated with the estimate: 80%); the middle value is on the limit's open side.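

Within the data shown here, compound 1, compound 2 and compound 3 each give only a limit, not a number, in this assay, so no step among them can be read. The compounds shown leave open whether any group at this place gives a measurable value.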